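Swapping the anilino substituent on a piperazinylpropoxy quinoline core

This account rests on a few compounds, and the source may have more. Where it says the series, first, only, none or still open, it means among the compounds named here.

Compound 1 `CN1CCN(CCCOc2cccc3nc(Nc4cccc(Cl)c4)ccc23)CC1` is the reference point. In a functional assay on cells (Panel breast (Carcinoma cell lines), Homo sapiens) for inhibition, read by sulforhodamine B assay, with a stated time of 48 h (on this read-out higher numbers stand for weaker inhibition of growth and lower numbers for stronger inhibition of growth), compound 1 gives 6690 nM, the highest of the two numbers recorded so far, so it is the weaker of the two at stopping growth. Among the measured compounds shown here, its nearest neighbour is compound 2 `CN1CCN(CCCOc2cccc3nc(Nc4ccc(Cl)c(F)c4)ccc23)CC1`, which in this assay gives 4500 nM; the step of a 1.5-fold lower number from compound 1 to compound 2 (0.17 log units; within the scatter) is the only measured step that bears on the new compound, and it does not rise beyond the usual scatter. Compound 3 `CN1CCN(CCCOc2cccc3nc(Nc4ccc(Cl)c(C(F)(F)F)c4)ccc23)CC1` is not yet measured. Relative to compound 1 it carries the change (4-chloro-3-(trifluoromethyl)phenyl in place of 3-chlorophenyl on a nitrogen on an aromatic ring). Since the comparable change to compound 2 produced only a 1.5-fold lower number from compound 1 to compound 2 (0.17 log units; within the scatter), the step of a 1.7-fold lower number from compound 1 to compound 3 (0.22 log units; within the scatter) is expected to be small and, if anything, toward stronger inhibition. For compound 3 in this assay the expected value is 4000 nM, with a range from 1500 nM to 11000 nM.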

Compound 3, concentration for total growth inhibition: 3630 nM
The estimate for compound 3 lay 1.1-fold (0.04 log units) above the measured number; the range from low to high includes it.
By their numbers in this assay, from the lowest: compounds 3, 2 and 1 (each within the scatter of the next).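

Replacing 3-chlorophenyl on the nitrogen with the larger 4-chloro-3-(trifluoromethyl)phenyl gives a 1.8-fold lower number from compound 1 to compound 3 (0.27 log units; within the scatter) in this assay, so even this bigger substituent does not shift the read-out beyond the scatter. Among the compounds shown here, putting trifluoromethyl in place of fluoro on the aromatic carbon gives a 1.2-fold lower number from compound 2 to compound 3 (0.09 log units; within the scatter), so the three compounds cannot be ranked, and the numbers so far show no clear effect of changing these substituents. No measurement is available to explain these small differences.

Going by these compounds, it remains open whether a group of a different kind on this aromatic ring, such as a carboxylic acid or an amine, would give a step beyond the scatter. The compounds shown also leave open what happens when the phenyl ring on the nitrogen carries no chlorine at all.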